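This account rests on a few compounds, and the source may have more. Where it says the series, first, only, none or still open, it means among the compounds named here.

Measured compounds:
compound 1 `O=c1ccoc2cc(OCc3cn(Cc4ccc(Br)cc4)nn3)ccc12` – > 100000 nM
compound 2 `O=c1ccoc2cc(OCc3cn(Cc4ccccc4Cl)nn3)ccc12` – > 100000 nM

Both values come from a functional assay on SGC-7901 cells (Homo sapiens) for cytotoxicity, read by MTT assay, with a stated time of 48 h; on this read-out higher numbers stand for weaker inhibition and lower numbers for stronger inhibition. The value for compound 1 is a limit of the assay, not a number. The value for compound 2 is likewise a limit. Among the measured compounds shown here, the one step between the two, a step that the two limits leave unreadable from compound 1 to compound 2, therefore cannot be read. Compound 2 thus stands at the top limit of the assay (the limit of > 100000 nM in this assay, at which 2 of the 2 values shown sit).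

Compound 3 `O=c1ccoc2cc(OCc3cn(Cc4ccccc4Br)nn3)ccc12` differs from compound 2 by bromo in place of chloro on an aromatic carbon. For the measured compounds named here, no measured step bears on this change, since the only step available is unreadable. Nothing therefore sets a size or a direction for the change in this assay, and no step beyond the scatter is expected. Compound 3 is estimated to give 100000 nM, with a range from 30000 nM to 300000 nM, which means an expected step of a number no higher from compound 2 to compound 3 (the limit leaves the size open).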

Compound 3, half-maximal inhibitory concentration: > 100000 nM
Compound 3 gave a limit, no number; the forecaster's own chance of this, stated with the estimate: 80%; the middle value lies on the limit itself.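

Compound 1, compound 2 and compound 3 each give only a limit, not a number, in this assay, so no step among them can be read: the limit of > 100000 nM in this assay, at which 3 of the 3 values shown sit.

The compounds shown leave open how far past that limit each one lies, and whether any change on the benzyl group would give a readable number.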